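The compounds below may be only part of what the source reports. "The series", "measured", "known", "first", "only" and "open" are said of these compounds alone.

Measured so far in a functional assay for inhibition, with Homo sapiens as the target; a higher number here means a weaker inhibitor, a lower number a stronger inhibitor:
compound 1 `O=C(O)CCCCCCn1nc(-c2ccccc2)c(-c2ccccc2)c1-c1ccccc1` gives 22400 nM
compound 2 `O=C(O)CCCCCCCn1nc(-c2ccccc2)c(-c2ccccc2)c1-c1ccccc1` gives 3400 nM
compound 3 `O=C(O)CS(=O)(=O)CCCCCCn1nc(-c2ccccc2)c(-c2ccccc2)c1-c1ccccc1` gives 22000 nM

Compound 1 has the highest number of the three. Compound 3 sits within the scatter of it, so no order between those two can be read; compound 2 is the only one clearly apart, with a 6.6-fold lower number from compound 1 to compound 2 (0.82 log units; beyond the scatter).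

Compound 4 `c1ccc(-c2nn(CCCCCCCCc3nnn[nH]3)c(-c3ccccc3)c2-c2ccccc2)cc1` is not yet measured. Its difference from compound 1: 2-(1H-tetrazol-5-yl)ethyl in place of carboxy on a saturated chain carbon, six bonds along the chain from an aromatic nitrogen

Two measured steps start from compound 1. a 6.6-fold lower number from compound 1 to compound 2 (0.82 log units; beyond the scatter) shows a modest gain on going from carboxy to carboxymethyl. a 1.0-fold lower number from compound 1 to compound 3 (0.01 log units; within the scatter) shows nothing beyond the scatter for (carboxymethyl)sulfonyl in place of carboxy, and a 6.5-fold higher number from compound 2 to compound 3 (0.81 log units; beyond the scatter) confirms the same spread from the other side. Among the compounds with values here, no measured step replaces a carboxy by a tetrazole, so that part of the change is not covered by the series. The entering group does carry its acidic ring further along the chain, in the direction of the step from compound 1 to compound 2, and a modest step in the same direction is expected, with wide uncertainty.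

Compound 4 is therefore expected at about 4000 nM, between 900 nM and 18000 nM. This estimate corresponds to an expected step of a 5.6-fold lower number from compound 1 to compound 4 (0.75 log units; beyond the scatter).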

Compound 4, half-maximal inhibitory concentration: 1040 nM
Beside the measured number, compound 4's estimate is 3.8-fold (0.59 log units) above it; measured number inside the range.
By their numbers in this assay, from the lowest: compound 4; then compound 2; then compounds 3 and 1 (each within the scatter of the next).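

In this assay, 2-(1H-tetrazol-5-yl)ethyl on this saturated chain carbon, six bonds along the chain from an aromatic nitrogen, gives the largest steps in the series: a 22-fold lower number from compound 1 to compound 4 (1.33 log units; beyond the scatter) and a 21-fold lower number from compound 3 to compound 4 (1.33 log units; beyond the scatter). A further change remains readable against the best carboxylic acid shown, a 3.3-fold lower number from compound 2 to compound 4 (0.51 log units; beyond the scatter), so compound 4 now has the lowest number of the four, clearly apart from each of the others. Nothing available gives a reason for these differences.

The entering group changes both the acid-bearing end and the chain length, and the compounds shown do not separate the two. Open, as far as these compounds go, are 1H-tetrazol-5-yl in place of carboxy on compound 1 with the chain unchanged, and 2-carboxyethyl in that same place, which would match the reach of compound 4 with a carboxylic acid.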